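Dimethylamino to diethylamino on the shared core

The source may report more compounds than this note shows. Statements on the series, on what has been measured and on what is new or still open speak of the compounds shown alone.

Compound 1 `CN(C)c1ccc2cc(NC(=O)CCc3ccc(C(F)(F)F)cc3)ccc2n1` is the reference point of this series. In a functional assay on HEK293 cells for activation of melanin-concentrating hormone receptor 1 (Rattus norvegicus), read by inositol phosphate accumulation (a higher number here means that more compound is needed for the effect, a lower number that less compound is needed), compound 1 gives 110 nM, the lowest of the three numbers measured; its nearest neighbour is compound 3 `O=C(CCc1ccc(C(F)(F)F)cc1)Nc1ccc2nc(N3CC4CC3CN4)ccc2c1`, which gives 490 nM, and the furthest is compound 2 `O=C(CCc1ccc(C(F)(F)F)cc1)Nc1ccc2nc(N3CCC(c4ccccc4)C3)ccc2c1`, which gives 1770 nM. Between the two larger groups the difference is a 3.6-fold lower number from compound 2 to compound 3 (0.56 log units; beyond the scatter).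

Compound 4 `CCN(CC)c1ccc2cc(NC(=O)CCc3ccc(C(F)(F)F)cc3)ccc2n1` is not yet measured. It differs from compound 1 in one place: diethylamino in place of dimethylamino on an aromatic carbon. The two measured steps bear directly on this change, as each also replaces dimethylamino on that aromatic carbon with something larger: a 16-fold higher number from compound 1 to compound 2 (1.21 log units; beyond the scatter), and a 4.5-fold higher number from compound 1 to compound 3 (0.65 log units; beyond the scatter). In both cases the number went up, and the larger group in compound 2 gave the larger rise. Diethylamino is a much smaller enlargement than either of those groups, and nothing among the measured compounds shows a change this small at that position. A rise that is modest at most, and possibly within the scatter, is therefore expected in this assay, namely a 2.0-fold higher number from compound 1 to compound 4 (0.30 log units; within the scatter). For compound 4 the estimate in this assay is 220 nM, with a range from 100 nM to 600 nM.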

Compound 4, half-maximal effective concentration: 830 nM
Compound 4: middle estimate off by 3.8-fold (0.58 log units), on the low side, outside the stated range (above it).
By their numbers in this assay, from the lowest: compound 1; then compounds 3 and 4 (each within the scatter of the next); then compound 2.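

In this assay the change from dimethylamino to diethylamino gives a 7.5-fold higher number from compound 1 to compound 4 (0.88 log units; beyond the scatter), so this position responds strongly to a change that adds no ring and leaves the counted hydrogen-bond donors and acceptors as they were. The rise also breaks any simple ordering by group size: the open-chain diethylamino of compound 4 and the larger two-ring group of compound 3 stand within the scatter of each other, at a 1.7-fold higher number from compound 3 to compound 4 (0.23 log units; within the scatter). Compound 2 remains apart, with a 2.1-fold lower number from compound 2 to compound 4 (0.33 log units; beyond the scatter), so among the groups at this position, only dimethylamino and 3-phenylpyrrolidin-1-yl are separated from diethylamino by more than the scatter, one on either side. Nothing available gives a reason for the rise from compound 1 to compound 4.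

Open, going by these compounds, is whether a methylamino group or a plain amino group at this position would keep the number of compound 1 or lower it, and whether an ethylmethylamino group would fall partway to compound 4. Also open, on these data alone, is what an unsubstituted pyrrolidin-1-yl group would give, which would separate the ring itself from the phenyl group carried by compound 2.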